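A few compounds are considered here, and "the series" means these few. Any claim that something is new, unique, unknown or untested is made for them only; others in the source may bear on it.

Measured compounds so far:

- compound 1 `O=C(Nc1cccc2cccnc12)c1cc(Br)cnc1O`; in a functional assay on HUVEC cells (Homo sapiens) for inhibition, read by ELISA and BrdU incorporation (a lower number here means a stronger inhibitor, a higher number a weaker inhibitor), compound 1 gives 560 nM
- compound 2 `O=C(Nc1cccc2cccnc12)c1cncc(Br)c1`; in this assay compound 2 gives 346 nM
- compound 3 `Cc1cc(Br)cc(C(=O)Nc2cnc3ccccc3c2)c1O`; in this assay compound 3 gives 470 nM

Compound 1 and compound 2 differ in one place: hydrogen in place of hydroxy on an aromatic carbon. That step, a 1.6-fold lower number from compound 1 to compound 2 (0.21 log units; within the scatter), is within the scatter, so the two values cannot be told apart.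

Compound 3 carries a different core from compound 1; the difference between the two cores is not broken down here. Its value sits within the scatter of both compound 1 and compound 2, so nothing can be said about an order among the three.

Compound 4 `Cc1cc(Br)cc(C(=O)Nc2cnc3ccccc3c2)c1` is not yet measured. It differs from compound 3 in one place: hydrogen in place of hydroxy on an aromatic carbon. This is the same kind of change as that from compound 1 to compound 2, not the same: in compound 1 the hydroxy sits on a six-membered aromatic ring with 1 nitrogen, next to the ring nitrogen, whereas in compound 3 it sits on a six-membered aromatic ring of carbon only, ortho to a methyl group.

For the measured compounds named here, for compound 4 in this assay a step of about a 1.5-fold lower number from compound 3 to compound 4 (0.17 log units; within the scatter) is expected, because a 1.6-fold lower number from compound 1 to compound 2 (0.21 log units; within the scatter) was within the scatter and no other pair tests the change. The estimate rests on one pair only, so the range is kept wide. Compound 4 is thus estimated at 320 nM, between 120 nM and 900 nM.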

Compound 4, half-maximal inhibitory concentration: 720 nM
The estimate for compound 4 lay 2.3-fold (0.35 log units) below the measured number; the range from low to high includes it.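

In this assay, hydrogen in place of hydroxy on the core of compound 3 gives a 1.5-fold higher number from compound 3 to compound 4 (0.19 log units; within the scatter), so this pair cannot be told apart, just as compound 1 and compound 2 could not. Set side by side, the two steps give no ground for saying that the change behaves differently on the two cores: the same change on two cores in this assay, a 1.6-fold lower number (0.21 log units; within the scatter) from compound 1 to compound 2 and a 1.5-fold higher number (0.19 log units; within the scatter) from compound 3 to compound 4, 2.5-fold (0.39 log units) apart, within the scatter of two such steps. This shows that, on both cores tested, the hydroxy can be exchanged for hydrogen without a readable difference in this assay; it does not show that the hydroxy is without effect or that the change transfers exactly, as two small steps within the scatter cannot establish either point, and in compound 3 the hydroxy also sits ortho to a methyl group, which makes the two settings unlike.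

The compounds shown hold only hydroxy or hydrogen at this carbon, so it remains open whether a methoxy group, an amine or a carboxylic acid there would give a step beyond the scatter on either core. From the compounds shown here alone, all four compounds also keep the bromo group and the amide link, so the part these play stays open, for example on replacing the bromo group with a chloro group or a nitrile.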